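This account rests on a few compounds, and the source may have more. Where it says the series, first, only, none or still open, it means among the compounds named here.

The series shares the core seen in compound 1 `CC(C)c1cc2c(N/N=C\c3ccncc3)ncnc2s1`, compound 2 `CC(C)(C)c1cc2c(N/N=C\c3cccnc3)ncnc2s1` and compound 3 `Cc1cccc(/C=N\Nc2ncnc3sc(C(C)(C)C)cc23)n1`, which differ in the aryl group attached to the carbon that carries the double bond to nitrogen. In a functional assay on PC-6 cells (Homo sapiens) for antiproliferative activity (on this read-out higher numbers stand for weaker inhibition and lower numbers for stronger inhibition), compound 1 gives only a limit, > 10 ug/mL, at which (the limit of > 10 ug/mL in this assay, at which 1 of the 3 values shown sits). Compound 2 gives 1.45 ug/mL in this assay, and compound 3 gives 0.258 ug/mL. Among the compounds with values here, compound 3 thus holds the lowest of the two numbers reported, and the single measured step, a 5.6-fold lower number from compound 2 to compound 3 (0.75 log units; beyond the scatter), lies beyond the scatter.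

Compound 4 `CN(C)Cc1cccc(/C=N\Nc2ncnc3sc(C(C)(C)C)cc23)n1` is not yet measured. It differs from compound 3 by dimethylamino in place of hydrogen on a saturated chain carbon bound to an aromatic carbon; cut one bond further out, the same difference reads methyl to (dimethylamino)methyl. Within the data shown here, no measured step touches this kind of change: the only step that is known, from compound 2 to compound 3, swaps one pyridyl ring for another and says nothing about a substituent on the methyl of compound 3. With no guide from the measured compounds, the expectation for compound 4 is a step of about a 1.4-fold higher number from compound 3 to compound 4 (0.13 log units; within the scatter), which is within the scatter. The estimate for compound 4 in this assay is therefore 0.35 ug/mL, with a range from 0.1 ug/mL to 1.3 ug/mL.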

Compound 4, half-maximal inhibitory concentration: 0.381 ug/mL
Compound 4: the middle estimate sits 1.1-fold (0.04 log units) below what was measured; the measured number falls inside the stated range.
By their numbers in this assay, from the lowest: compounds 3 and 4 (each within the scatter of the next); then compound 2. At a limit, above all of these: compound 1.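

In this assay, replacing methyl with (dimethylamino)methyl gives a 1.5-fold higher number from compound 3 to compound 4 (0.17 log units; within the scatter), so on this saturated chain carbon bound to an aromatic carbon, dimethylamino in place of hydrogen leaves the number within the scatter. Within the data shown here, the earlier compounds gave no reading at this place, as their one measured step swapped one pyridyl ring for another; this pair is the first to show that the ring's methyl can carry an added group, here one with a nitrogen and no ring, with no change beyond the scatter. Nothing in the data shown accounts for this result, and the single pair supports no rule for the position as a whole.

The compounds shown leave open whether this tolerance extends to other groups on the same carbon, such as a primary amine, a carboxylic acid or a longer chain ending in an amine. They also leave open whether (dimethylamino)methyl would act the same way on another aryl group of the series, such as the pyridin-3-yl of compound 2.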